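The source may hold more compounds than are shown below. What is called first, only, known or untested is meant among the compounds shown, and "the series" means these compounds.

Of the compounds shown here, three with a shared core have been read in a physicochemical assay for solubility, read by chemiluminescence, measured as kinetic solubility (on this read-out higher numbers stand for higher solubility and lower numbers for lower solubility), and none of them has yet given a number. Compound 1 `COc1nn(C)c2ncnc(NS(=O)(=O)c3cccc(Cl)c3Cl)c12` gives >= 581000 nM, which is a limit. Compound 2 `COc1nn(CC(N)=O)c2ncnc(NS(=O)(=O)c3cccc(Cl)c3Cl)c12` gives >= 490000 nM, which is also a limit. Compound 3 `COCCn1nc(OC)c2c(NS(=O)(=O)c3cccc(Cl)c3Cl)ncnc21` gives >= 442000 nM, and this too is a limit. Compound 3 therefore has no exact place on the scale, and the two other values offer no number to set it against.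

Compound 4 `COc1nn(C2COC2)c2ncnc(NS(=O)(=O)c3cccc(Cl)c3Cl)c12` keeps the shared core and differs from compound 3 in one group: oxetan-3-yl in place of 2-methoxyethyl on an aromatic nitrogen. Oxetan-3-yl takes the place of 2-methoxyethyl on an aromatic nitrogen, so a ring replaces an open chain.

Going by the values given here, three measured steps bear on this change, as each alters the group on that same nitrogen: a step that the two limits leave unreadable from compound 1 to compound 2, a step that the two limits leave unreadable from compound 1 to compound 3 and a step that the two limits leave unreadable from compound 2 to compound 3. None of them has a readable size, and none gives a direction. The data thus offer no ground for expecting a real shift in this assay. The expected step is a step that the limit leaves unreadable from compound 3 to compound 4, with no move beyond the scatter anticipated in either direction. For compound 4 the estimated value is 450000 nM, with an expected range from 200000 nM to 620000 nM.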

Compound 4, solubility: 142000 nM
The estimate for compound 4 lay 3.2-fold (0.50 log units) above the measured number; the measured number lies below the stated range.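

Going by these compounds alone, compound 4 is the only one of the four compounds with an actual number in this assay, and it shows that the group on this aromatic nitrogen can move the read-out beyond the scatter, which the earlier compounds could not show, as the steps among them cannot be read. Oxetan-3-yl and 2-methoxyethyl both count 4 heavy atoms, yet closing the chain into the four-membered ring gives an at least 3.1-fold lower number from compound 3 to compound 4 (0.49 log units; beyond the scatter), while oxetan-3-yl in place of carbamoylmethyl gives an at least 3.4-fold lower number from compound 2 to compound 4 (0.53 log units; beyond the scatter) and oxetan-3-yl in place of methyl gives an at least 4.0-fold lower number from compound 1 to compound 4 (0.61 log units; beyond the scatter). All three steps are minimum sizes, since each starts from a limit and not from a number, and for compound 3 that limit reads: the limit of >= 442000 nM in this assay, at which 1 of the 4 values shown sits.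

The compounds shown leave open whether the lower number goes with any four-membered ring on this nitrogen or with oxetan-3-yl alone, a question that cyclobutyl or azetidin-3-yl at the same place would address. Within the data shown here, also open is how the earlier compounds rank among themselves, and where an open chain ending in an amine or a carboxylic acid would fall on this scale.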